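A methoxyphenyl swap on the amine nitrogen

A few compounds are considered here, and "the series" means these few. Any claim that something is new, unique, unknown or untested is made for them only; others in the source may bear on it.

Values in a functional assay on ECa-109 cells for inhibition, with ECa-109 cell line (Homo sapiens) as the target, read by sulforhodamine B assay; a higher number here means a weaker inhibitor, a lower number a stronger inhibitor:
- compound 1 `O=C1C(Nc2ccccc2F)=CC(=O)c2c1nc1n2[C@H]2OC[C@@H](O)[C@H]2OC1`: 2660 nM
- compound 2 `CCc1ccc(NC2=CC(=O)c3c(nc4n3[C@H]3OC[C@@H](O)[C@H]3OC4)C2=O)cc1`: > 4000 nM (a limit of the assay, not a number)
- compound 3 `Cc1ccc(NC2=CC(=O)c3c(nc4n3[C@H]3OC[C@@H](O)[C@H]3OC4)C2=O)cc1C`: 4090 nM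

Compound 3 stands within the scatter of compound 1, showing a 1.5-fold higher number from compound 1 to compound 3 (0.19 log units; within the scatter). Its comparison with the limit gives a step that the limit leaves unreadable from compound 2 to compound 3.

Compound 4 `COc1ccc(NC2=CC(=O)c3c(nc4n3[C@H]3OC[C@@H](O)[C@H]3OC4)C2=O)cc1` carries 4-methoxyphenyl in place of 3,4-dimethylphenyl on an amine nitrogen. This exact change has not been measured. The nearest evidence is the other swaps on that nitrogen, an at least 1.5-fold higher number from compound 1 to compound 2 (0.17 log units; that floor lies within the scatter) and a 1.5-fold higher number from compound 1 to compound 3 (0.19 log units; within the scatter), so no step beyond the scatter is expected in this assay. The estimated step is a 1.2-fold lower number from compound 3 to compound 4 (0.07 log units; within the scatter). For compound 4 the expected value is 3500 nM, with an estimated range of 1700 nM to 7000 nM.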

Compound 4, half-maximal inhibitory concentration: 3410 nM
The estimate for compound 4 lay 1.0-fold (0.01 log units) above the measured number; the measured number falls inside the stated range.
By their numbers in this assay, from the lowest: compounds 1, 4 and 3 (each within the scatter of the next).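

In this assay, 4-methoxyphenyl brings a hydrogen-bond acceptor onto the amine nitrogen, yet the value stays within the scatter of both measured neighbours (a 1.2-fold lower number from compound 3 to compound 4 (0.08 log units; within the scatter); a 1.3-fold higher number from compound 1 to compound 4 (0.11 log units; within the scatter)). Compound 2 gives a limit, not a number: the limit of > 4000 nM in this assay, at which 1 of the 4 values shown sits. Methoxy in place of ethyl on an aromatic carbon can therefore be read only as a floor (an at least 1.1-fold lower number from compound 2 to compound 4 (0.06 log units; that floor lies within the scatter)).

Going by these compounds, it remains open whether a carboxylic acid on the phenyl ring, or a morpholine in place of the phenyl ring, would move the value beyond the scatter.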